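From compound 1 to compound 3: a larger ring

The source may hold more compounds than are shown below. What is called first, only, known or untested is meant among the compounds shown, and "the series" means these compounds.

Among the compounds with values here, compound 1 `O=C(CCC1CCCC1)N(O)c1ccc(Cl)cc1` gives 10000 nM in a functional assay on SW-620 cells (Homo sapiens) for inhibition (a lower number here means a stronger inhibitor, a higher number a weaker inhibitor), the highest of the two numbers measured so far; its nearest neighbour, compound 2 `O=C(CC1CCCCC1)N(O)c1ccc(Cl)cc1`, gives 9000 nM in this assay, and a 1.1-fold lower number from compound 1 to compound 2 (0.05 log units; within the scatter). Compound 3 `O=C(CCC1CCCCC1)N(O)c1ccc(Cl)cc1` differs from compound 1 by cyclohexyl in place of cyclopentyl on a saturated chain carbon, two bonds along the chain from a carbonyl carbon. Within the data shown here, the only measured step that bears on this is a 1.1-fold lower number from compound 1 to compound 2 (0.05 log units; within the scatter), which also brought in cyclohexyl, so no step beyond the scatter is expected in this assay. Compound 3 is therefore estimated at 9000 nM, within 4000 nM to 20000 nM, which amounts to a 1.1-fold lower number from compound 1 to compound 3 (0.05 log units; within the scatter).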

Compound 3, half-maximal inhibitory concentration: 20000 nM
Compound 3: the middle estimate sits 2.2-fold (0.35 log units) below what was measured; the range from low to high includes it.
By their numbers in this assay, from the lowest: compounds 2, 1 and 3 (each within the scatter of the next, the first and the last beyond it).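

With the chain kept and only the ring changed, cyclohexyl in place of cyclopentyl gives a 2.0-fold higher number from compound 1 to compound 3 (0.30 log units; within the scatter) in this assay and so does not shift the result beyond the scatter. The step from compound 1 to compound 2 had altered the chain and the ring together, whereas this one isolates ring size at this place. No available evidence bears on this result. Going by these compounds, whether an amine, a carboxylic acid or a phenyl ring in place of the cyclohexyl would give a step beyond the scatter remains open, as does the effect of a longer chain.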